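The source may report more compounds than this note shows. Statements on the series, on what has been measured and on what is new or still open speak of the compounds shown alone.

Three esters of a shared core have been measured in an assay on isolated protein for antagonist activity at Bile acid receptor (Homo sapiens), read by HTRF, with a stated time of 30 min; a lower number here means a stronger inhibitor, a higher number a weaker inhibitor. Compound 1 `CC(C)(C)c1cc(OC(=O)c2ccc(Cl)cc2Cl)ccc1O` gives 10200 nM. Compound 2 `CC(C)(C)c1cc(OC(=O)/C=C/c2ccccc2)ccc1O` reaches only the limit of the assay, reported as > 100000 nM. Compound 3 `CC(C)(C)c1cc(OC(=O)c2ccco2)ccc1O` also reaches only the limit of the assay, reported as > 100000 nM. Compound 3 therefore stands at the limit of > 100000 nM in this assay, at which 2 of the 3 values shown sit, and on the numbers shown it cannot be separated from compound 2.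

Compound 4 `Cc1ccc(C(=O)Oc2ccc(O)c(C(C)(C)C)c2)cc1` has not yet been measured. It differs from compound 3 in one place: 4-methylphenyl in place of furan-2-yl on a carbonyl carbon. Among the measured compounds shown here, no pair of measured compounds differs in only one place, so the size of this step cannot be read from any measured step. One hint comes from compound 1, which also carries a six-membered aromatic ring of carbon only on the carbonyl carbon and gives a number, 10200 nM, rather than a limit. On that basis the step from compound 3 to compound 4 is expected to be an at least 2.5-fold lower number from compound 3 to compound 4 (0.39 log units; beyond the scatter), a modest move towards stronger inhibition. Compound 4 is expected to give about 40000 nM, within a range from 10000 nM to 150000 nM.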

Compound 4, half-maximal inhibitory concentration: > 100000 nM
Compound 4: only a limit was reported; the forecaster's own chance of this, stated with the estimate: 45%; middle value at least 2.5-fold (0.39 log units) away from the limit.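

No step can be read between compound 3 and compound 4, since each gives only a limit: the limit of > 100000 nM in this assay, at which 3 of the 4 values shown sit. The compounds shown leave open how weak compound 3 and compound 4 really are, and whether 4-methylphenyl in place of furan-2-yl changes inhibition at all.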